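A few compounds are considered here, and "the series" means these few. Any claim that something is new, unique, unknown or untested is made for them only; others in the source may bear on it.

Measured compounds:
Compound 1 `COc1cccc(/C=C/C(=O)c2sc(Nc3cccc(C)c3)nc2C)c1` — in a functional assay on BGC-823 cells (Homo sapiens) for cytotoxicity, read by MTT assay (a higher number here means a weaker inhibitor, a lower number a stronger inhibitor), compound 1 gives > 25000 nM, which is a limit of the assay and not a number.
Compound 2 `Cc1nc(Nc2ccc(Cl)c(Cl)c2)sc1C(=O)/C=C/c1ccc(Cl)cc1` — in this assay compound 2 gives 22700 nM.
Compound 3 `Cc1cccc(Nc2nc(C)c(C(=O)/C=C/c3ccc(Cl)cc3)s2)c1` — in this assay compound 3 gives > 25000 nM, again a limit of the assay.

Within the data shown here, compound 2 therefore stands as the only compound of the three with a number in this assay; the other two sit at the limit of > 25000 nM in this assay, at which 2 of the 3 values shown sit. From compound 2 to compound 3 the change at the nitrogen on the aromatic ring gives an at least 1.1-fold higher number from compound 2 to compound 3 (0.04 log units; that floor lies within the scatter). The change now in question, (3-methoxyphenyl in place of 4-chlorophenyl on a double-bonded chain carbon bound to a double-bonded chain carbon), leads to compound 4 `COc1cccc(/C=C/C(=O)c2sc(Nc3ccc(Cl)c(Cl)c3)nc2C)c1`. Among the measured compounds shown here, the one measured step that bears on the same place, read in the opposite direction, is a step that the two limits leave unreadable from compound 1 to compound 3, so its size is not readable; both ends of it are limits. For the measured compounds named here, no measured step gives a direction for this change, so no step beyond the scatter is expected in this assay, and a limit rather than a number is the more likely outcome for compound 4. The expectation for compound 4 is 28000 nM, with a range from 12000 nM to 60000 nM. This estimate for compound 4 means a step of a 1.2-fold higher number from compound 2 to compound 4 (0.09 log units; within the scatter).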

Compound 4, half-maximal inhibitory concentration: 8350 nM
Compound 4: the middle estimate sits 3.4-fold (0.53 log units) above what was measured, outside the stated range (below it).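

On the double-bonded chain carbon bound to a double-bonded chain carbon, the change between 4-chlorophenyl and 3-methoxyphenyl now has a readable size in this assay: with 3,4-dichlorophenyl on the nitrogen, 3-methoxyphenyl in place of 4-chlorophenyl gives a 2.7-fold lower number from compound 2 to compound 4 (0.43 log units; beyond the scatter), whereas the same change with 3-methylphenyl on the nitrogen has limits at both ends and cannot be read. The change at the nitrogen also gains a direction on the core carrying 3-methoxyphenyl, where 3,4-dichlorophenyl in place of 3-methylphenyl gives an at least 2.9-fold lower number from compound 1 to compound 4 (0.47 log units; beyond the scatter). Whether this change at the nitrogen has the same size on the two cores remains unresolved: the same change on two cores in this assay, an at least 1.1-fold higher number (0.04 log units; that floor lies within the scatter) from compound 2 to compound 3 and an at least 2.9-fold higher number (0.47 log units; beyond the scatter) from compound 4 to compound 1; the limit leaves it open whether they differ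

With 3-methylphenyl on the nitrogen, compound 1 and compound 3 both stay at a limit, so the change on the chain carbon remains unreadable on that core: the limit of > 25000 nM in this assay, at which 2 of the 4 values shown sit.

Going by these compounds, it also remains open whether the lower number of compound 4 depends on the methoxy group itself, which an amine or a carboxylic acid in its place on the phenyl ring would test in this assay.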